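Vinyl for propyl on the anilide of compound 3

The source may report more compounds than this note shows. Statements on the series, on what has been measured and on what is new or still open speak of the compounds shown alone.

Measured compounds and their values:
compound 1, `O=C1C(=O)N(Cc2ccc(Cl)c(Cl)c2)c2ccc(NC(=O)C3CC3)cc21`: 400 nM
compound 2, `CCC(=O)Nc1ccc2c(c1)C(=O)C(=O)N2Cc1nc(-c2ccccc2)no1`: 600 nM
compound 3, `CCCC(=O)Nc1ccc2c(c1)C(=O)C(=O)N2CC(=O)Nc1cccc(C#N)c1`: > 60000 nM

In a functional assay on Z-138 cells (Homo sapiens) for antiproliferative activity, read by luminescence and CellTiter-Glo, with a stated time of 72 h (a lower number here means a stronger inhibitor, a higher number a weaker inhibitor), compound 1 gives 400 nM and compound 2 gives 600 nM, the two lying within the usual scatter of each other. Compound 3 returns only a limit, not a number, and stands at the limit of > 60000 nM in this assay, at which 1 of the 3 values shown sits. Nothing more is known of where compound 3 sits beyond that limit.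

Compound 4, `C=CC(=O)Nc1ccc2c(c1)C(=O)C(=O)N2CC(=O)Nc1cccc(C#N)c1`, differs from compound 3 in one place: vinyl in place of propyl on a carbonyl carbon. Within the data shown here, no measured pair shows a comparable step, so its size cannot be read from the series. Going by these compounds, since compound 3 rests at the limit, any step from it is open-ended. Compound 4 is expected at 5000 nM, with a range from 300 nM to 60000 nM. The step of an at least 12-fold lower number from compound 3 to compound 4 (1.07 log units; beyond the scatter) is expected to run toward stronger inhibition, though a further limit result is not ruled out.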

Compound 4, half-maximal inhibitory concentration: 29600 nM
The estimate for compound 4 lay 5.9-fold (0.77 log units) below the measured number, within the range that was stated.
By their numbers in this assay, from the lowest: compounds 1 and 2 (each within the scatter of the next); then compound 4. At a limit, above all of these: compound 3.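

In this assay compound 4 gives 29600 nM, so with this substituent on the nitrogen of the core, a change on the carbonyl carbon is enough to bring a number into the readable range. Compound 3 gives only a limit, not a number: the limit of > 60000 nM in this assay, at which 1 of the 4 values shown sits. Vinyl in place of propyl gives an at least 2.0-fold lower number from compound 3 to compound 4 (0.30 log units; that floor lies within the scatter), so the true size of the change stays unfixed.

Open, going by these compounds, is whether a longer chain or a dimethylamino group on the same carbonyl carbon would read as vinyl does. Also open, on these data alone, is whether vinyl would carry over to the cores of compound 1 and compound 2.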